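Swapping the amine-bearing side chain on the shared core

A few compounds are considered here, and "the series" means these few. Any claim that something is new, unique, unknown or untested is made for them only; others in the source may bear on it.

Compound 1 `NC1CCN(c2nc3c(c(Nc4ccc(C(F)(F)F)cc4)n2)CCN(c2ncccc2C(F)(F)F)CC3)C1` and compound 2 `CN1CCCCC1CNc1nc2c(c(Nc3ccc(C(F)(F)F)cc3)n1)CCN(c1ncccc1C(F)(F)F)CC2` share one core and differ only in the group that sits on an aromatic carbon of the six-membered aromatic ring with two nitrogen atoms. In a functional assay on HEK293 cells for antagonist activity at transient receptor potential cation channel subfamily V member 1 (Rattus norvegicus), read by FLIPR and calcium flux (on this read-out higher numbers stand for weaker inhibition and lower numbers for stronger inhibition), compound 1 reaches only a limit, > 5000 nM, and not a number. In this assay, among the measured compounds shown here, compound 2 gives 2280 nM, the only plain number in this small set. The measured step of an at least 2.1-fold lower number from compound 1 to compound 2 (0.34 log units; beyond the scatter) goes beyond the scatter, although its size is bounded by the limit of > 5000 nM in this assay, at which 1 of the 2 values shown sits.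

Compound 3 `CC(=O)NC1CCN(c2nc3c(c(Nc4ccc(C(F)(F)F)cc4)n2)CCN(c2ncccc2C(F)(F)F)CC3)C1` is not yet measured. It differs from compound 2 by 3-acetamidopyrrolidin-1-yl in place of ((1-methylpiperidin-2-yl)methyl)amino on an aromatic carbon. For the measured compounds named here, the only measured step that bears on this change is an at least 2.1-fold lower number from compound 1 to compound 2 (0.34 log units; beyond the scatter), since compound 3 returns to a pyrrolidin-1-yl group on the same aromatic carbon, now carrying an acetamido rather than an amino substituent. On that basis a rise in the number, in the direction of compound 1, is expected, with the step of a 1.8-fold higher number from compound 2 to compound 3 (0.24 log units; within the scatter) estimated. The estimate for compound 3 in this assay is 4000 nM, within a range from 1200 nM to 15000 nM, and a limit rather than a number is quite possible.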

Compound 3, half-maximal inhibitory concentration: 410 nM
The estimate for compound 3 lay 9.8-fold (0.99 log units) above the measured number, outside the stated range (below it).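

The earlier pair placed the ((1-methylpiperidin-2-yl)methyl)amino group ahead of the 3-aminopyrrolidin-1-yl group, but in this assay the 3-acetamidopyrrolidin-1-yl group goes further still, with a 5.6-fold lower number from compound 2 to compound 3 (0.75 log units; beyond the scatter). A five-membered ring on this aromatic carbon, between two ring nitrogen atoms, therefore does not by itself keep the number high. The substituent on that ring matters much more than the first pair could show, as acetyl in place of hydrogen on the amine nitrogen gives an at least 12-fold lower number from compound 1 to compound 3 (1.08 log units; beyond the scatter), although compound 1 stands at a limit and not a number, which bounds the size of this step: the limit of > 5000 nM in this assay, at which 1 of the 3 values shown sits.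

The compounds shown leave open whether the acetyl group is specifically required, or whether a methyl group, a methanesulfonyl group or a longer acyl chain such as propanoyl on the same nitrogen would lower the number as far. They also leave open whether an acetamido group carried on a six-membered piperidine ring, in place of the pyrrolidine ring, would give a similar step.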